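Carbamate, cyanamide and hydrazine on the shared aminopyrimidine core

The compounds below may be only part of what the source reports. "The series", "measured", "known", "first", "only" and "open" are said of these compounds alone.

Compound 1, `CC(C)(C)c1nc(NC#N)ncc1-c1ccccc1`, in a functional assay on the whole organism for inhibition, with Rattus norvegicus as the target, with stated times of 1 h and 3.5 h, at a dose of 100 mg/kg by the oral route (on this read-out higher numbers stand for more inhibition at the one dose given (going by the name of the read-out) and lower numbers for less inhibition), gives only the assay limit < 5%.
Compound 2, `CCOC(=O)Nc1ncc(-c2ccccc2)c(C(C)(C)C)n1`, in this assay gives 24%.

Among the measured compounds shown here, compound 2 stands as the only compound of the pair with a number rather than a limit; its value is the single read value shown in this assay. The other entry, (the limit of < 5% in this assay, at which 1 of the 2 values shown sits), is a limit and not a number.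

For the measured compounds named here, one measured step bears on the series: a number at least 19 percentage points higher from compound 1 to compound 2 (beyond the scatter). It shows that what sits on the ring nitrogen can move the read-out beyond the scatter, with the ethoxycarbonyl group giving the higher number.

Compound 3, `CC(C)(C)c1nc(NN)ncc1-c1ccccc1`, is the next compound. Its change from compound 2 is amino in place of ethoxycarbonyl on a nitrogen on an aromatic ring. Going by the values given here, no measured step covers amino on this nitrogen, so the direction is not fixed by the data; the only guidance is that removing the ethoxycarbonyl group from the carbamate compound leaves a smaller substituent, and the one small substituent seen (the cyano of compound 1) sits at the limit.

Compound 3 is therefore expected to give about 10% in this assay, with a range from 0% to 30%. The step of a number 14 percentage points lower from compound 2 to compound 3 (beyond the scatter) is expected to be a downward one, with a fair chance that only a limit is reported.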

Compound 3, a percentage reported as inhibition, in the whole organism at one dose (the size of the read-out at that dose, not a potency): < 5%
Compound 3: only a limit was reported; the forecaster's own chance of this, stated with the estimate: 40%; middle value at least 5 percentage points away from the limit.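

Amino in place of ethoxycarbonyl on a nitrogen on an aromatic ring gives a number at least 19 percentage points lower from compound 2 to compound 3 (beyond the scatter), so in this assay a second replacement of the ethoxycarbonyl group, different from cyano, also ends in a lower read-out. Of the three groups shown on this nitrogen, only ethoxycarbonyl gives a number, while cyano and amino both end in a limit, so the higher read-out of the carbamate is no longer tied to a single comparison. The step from cyano to amino cannot be read, and no order between these two groups can be given: the limit of < 5% in this assay, at which 2 of the 3 values shown sit.

On these data alone, it remains open whether the read-out depends on the whole ethoxycarbonyl group or on only part of it, a question that methoxycarbonyl, butoxycarbonyl with its longer chain, or acetyl on the same nitrogen would address. Among the compounds shown here, with only one number in the set, it is also open how far the read-out can rise at this place, and how a plain amine, carrying only hydrogen on this nitrogen, would compare.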